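Ring nitrogen methylation across two aryl variants

The compounds below may be only part of what the source reports. "The series", "measured", "known", "first", "only" and "open" are said of these compounds alone.

Measured compounds:
compound 1 `Fc1ccc(C2=CC3CNCC(C2)C3)cn1`, an in vitro assay on SH-SY5Y cells for displacement of a labelled ligand from Neuronal acetylcholine receptor; alpha3/beta4 (Homo sapiens); on this read-out higher numbers stand for weaker inhibition and lower numbers for stronger inhibition: 28 nM
compound 2 `CN1CC2C=C(c3ccc(F)nc3)CC(C2)C1`, this assay: 1310 nM
compound 3 `CC(C)Oc1cncc(C2=CC3CNCC(C2)C3)c1`, this assay: 4.8 nM

Compound 1 and compound 2 share one core and differ only where a methyl has replaced hydrogen (methyl in place of hydrogen on an amine nitrogen in a ring). That change produced a 47-fold higher number from compound 1 to compound 2 (1.67 log units; beyond the scatter), a large weakening of binding.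

Compound 3 carries a different aryl group on the same bicyclic amine; the difference between the core of compound 1 and that of compound 3 is not broken down here. Among the three measured compounds, compound 3 gives the lowest number, and its nearest neighbour is compound 1.

Compound 4 `CC(C)Oc1cncc(C2=CC3CC(C2)CN(C)C3)c1` has not yet been measured. It stands to compound 3 as compound 2 stands to compound 1: a methyl in place of hydrogen (methyl in place of hydrogen on an amine nitrogen in a ring). The place of the change is described in the same words for both pairs, so this is the same change made on a second aryl variant. For the measured compounds named here, with only one prior instance of the change, the expectation for compound 4 rests on that single step.

Starting from compound 3 at 4.8 nM, and carrying over the size of the step seen in a 47-fold higher number from compound 1 to compound 2 (1.67 log units; beyond the scatter), compound 4 is expected to show a 46-fold higher number from compound 3 to compound 4 (1.66 log units; beyond the scatter). On that basis compound 4 is estimated at 220 nM in this assay. The range expected for compound 4 runs from 60 nM to 900 nM.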

Compound 4, inhibition constant: 1730 nM
Estimate against measurement, compound 4: 7.9-fold (0.90 log units) below; measured number above the stated range.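

Methyl in place of hydrogen on an amine nitrogen in a ring weakens binding on both aryl variants in this assay, and the new pair gives a 360-fold higher number from compound 3 to compound 4 (2.56 log units; beyond the scatter), so in these two pairs the direction of the change carries from one core to the other. The size of the step does not carry over unchanged, and a single step taken from one core is therefore a poor guide to its exact size on the other: the same change on two cores in this assay, a 47-fold higher number (1.67 log units; beyond the scatter) from compound 1 to compound 2 and a 360-fold higher number (2.56 log units; beyond the scatter) from compound 3 to compound 4, 7.7-fold (0.89 log units) apart, beyond the scatter of two such steps. Two pairs do not show which feature of the aryl group goes with the larger step, nor do they give a general rule for the size of the change, and they say nothing of why the two steps differ.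

Still open, on these data alone, is how the step behaves on other aryl groups, for example one carrying a nitrile, a carboxylic acid or an amine in place of the fluoro or isopropoxy group. Also open, as far as these compounds go, is whether a group larger than methyl on the same nitrogen, such as ethyl or a longer chain, follows the same direction and how its step varies from core to core.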